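A few compounds are considered here, and "the series" means these few. Any claim that something is new, unique, unknown or untested is made for them only; others in the source may bear on it.

Measured so far in an assay on membranes from brain for binding affinity to adenosine receptor A1 (Rattus norvegicus), read by radioligand binding, tested at 20 uM; on this read-out higher numbers stand for more inhibition at the one concentration tested (going by the name of the read-out) and lower numbers for less inhibition:

compound 1, `Cn1c(=O)[nH]c2c(cnn2-c2ccccc2F)c1=N` — 8%
compound 2, `Cn1c(=O)[nH]c2c(cnn2-c2ccc(Cl)cc2Cl)c1=N` — 9%

Both compounds hold the same core and differ only in the substitution of the aromatic ring on the ring nitrogen. In this assay compound 2 gives 9%, and in the same this assay compound 1 gives 8%; the two figures lie within the usual scatter of one another, so neither is set apart from the other, and both signal little inhibition at the concentration tested.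

Compound 3, `Cn1c(=O)[nH]c2c(cnn2-c2ccccc2Cl)c1=N`, is the next compound to enter this assay. Its difference from compound 2: hydrogen in place of chloro on an aromatic carbon.

Among the measured compounds shown here, no measured pair in this assay shows what this change does. With both measured compounds sitting low and close together, no step beyond the scatter is expected in either direction. For compound 3 an inhibition of 8% is estimated, in the range 0% to 20%. This estimate amounts to an expected step of a number 1 percentage points lower from compound 2 to compound 3 (within the scatter), inside the scatter.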

Compound 3, a percentage reported as inhibition, at one concentration (the size of the read-out at that concentration, not a potency): 7%
Beside the measured number, compound 3's estimate is 1 percentage points above it; low and high end bracket the measured number.
By their numbers in this assay, from the lowest: compounds 3, 1 and 2 (each within the scatter of the next).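

In this assay hydrogen in place of chloro on an aromatic carbon, para to a large group and meta to a chloro group, gives a number 2 percentage points lower from compound 2 to compound 3 (within the scatter) and so does not set the two groups apart at this position. Chloro in place of fluoro on an aromatic carbon gives a number 1 percentage points lower from compound 1 to compound 3 (within the scatter) and offers the first one-place comparison of these two halogens, which are not set apart either. Nothing at hand bears on the reason for either step.

Going by these compounds, all three compounds remain low at the one concentration tested, so it stays open whether any group on this aromatic ring can raise the inhibition clearly above this level. An amine, a carboxylic acid or a longer chain at this position would test whether the flat picture extends beyond hydrogen and halogens.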